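Aryl amide exchange at the carbonyl end of compound 1

The source may report more compounds than this note shows. Statements on the series, on what has been measured and on what is new or still open speak of the compounds shown alone.

Compound 1 `Cc1ccc(S(=O)(=O)N[C@@H](CC(=O)NC(C)(C)C)C(=O)NCCNC(=O)c2cc(Cl)ccn2)cc1` is one of three compounds read in an ADME assay on HepG2 cells (Homo sapiens) for cytotoxicity; a higher number here means that more compound is needed for the effect, a lower number that less compound is needed. In this assay compound 1 gives > 11000 nM, which is a limit of the assay and not a number. Compound 2 `Cc1ccc(S(=O)(=O)N[C@@H](CC(=O)NC(C)(C)C)C(=O)NCCNC(=O)c2ccc(Cl)cc2)cc1` gives > 11000 nM in this assay, again a limit. Compound 3 `Cc1ccc(S(=O)(=O)N[C@@H](CC(=O)NC(C)(C)C)C(=O)NCCNC(=O)c2ccccn2)cc1` gives > 11000 nM in this assay, also a limit. The measured steps are therefore unreadable: a step that the two limits leave unreadable from compound 1 to compound 2, a step that the two limits leave unreadable from compound 1 to compound 3 and a step that the two limits leave unreadable from compound 2 to compound 3. All three readings sit at the limit of > 11000 nM in this assay, at which 3 of the 3 values shown sit.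

Compound 4 `Cc1ccc(S(=O)(=O)N[C@@H](CC(=O)NC(C)(C)C)C(=O)NCCNC(=O)c2ccccc2O)cc1` differs from compound 1 by 2-hydroxyphenyl in place of 4-chloropyridin-2-yl on a carbonyl carbon. Going by the values given here, no measured step covers a 2-hydroxyphenyl on this carbonyl carbon; the measured pairs exchange 4-chloropyridin-2-yl, 4-chlorophenyl and pyridin-2-yl, and all three sit at the same limit, so neither size nor direction can be read from them. No step beyond the scatter is expected. The estimate for compound 4 in this assay is 15000 nM, with an expected range from 6000 nM to 40000 nM, and most likely only a limit will be reported again. The expected step is a step that the limit leaves unreadable from compound 1 to compound 4.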

Compound 4, half-maximal effective concentration: > 11000 nM
Compound 4 gave a limit, no number (the forecaster's own chance of this, stated with the estimate: 80%); the middle value does not contradict the limit.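

In this assay compound 4 gives > 11000 nM, a limit and not a number. The steps linking compound 4 with compounds 1, 2 and 3 therefore cannot be read, and the series stays at one ceiling: the limit of > 11000 nM in this assay, at which 4 of the 4 values shown sit.

The compounds shown leave open whether any of these four aryl amides differs from the others in cytotoxicity, and by how much.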